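This account rests on a few compounds, and the source may have more. Where it says the series, first, only, none or still open, it means among the compounds named here.

In an ADME assay on HEK293 cells for agonist activity at Toll-like receptor 8 (Homo sapiens), read by a luciferase reporter, with a stated time of 6 h (a lower number here means that less compound is needed, a higher number that more compound is needed for the effect), the three measured compounds stand as follows:

Compound 1, `CCCCNc1nc(N)nc2cc(OC)ccc12`: 0.3 uM
Compound 2, `CCCCNc1nc(N)nc2cc(CO)ccc12`: 0.1 uM
Compound 3, `CCCCNc1nc(N)nc2ccc(OC)cc12`: 1.8 uM

Compound 1 and compound 2 share a core and differ in one place: hydroxymethyl in place of methoxy on an aromatic carbon. That change brought a 3.0-fold lower number from compound 1 to compound 2 (0.48 log units; beyond the scatter) in this assay. Compound 3 carries the same substituent as compound 1 but on a different core; how the two cores differ is not broken down here. In this assay compound 3 has the highest number of the three, and its gap to compound 1 as well as to compound 2 lies beyond the scatter.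

Compound 4, `CCCCNc1nc(N)nc2ccc(CO)cc12`, is not yet measured. Among the measured compounds shown here, it is made from compound 3 by the change (hydroxymethyl in place of methoxy on an aromatic carbon), which is the same change, at the same kind of place, as the one that led from compound 1 to compound 2. For the measured compounds named here, with only one earlier example of this change, the expectation for compound 4 rests on that single step: compound 3, with 1.8 uM, is expected to move by about the same amount as compound 1 did when it became compound 2, that is a 3.0-fold lower number from compound 1 to compound 2 (0.48 log units; beyond the scatter). The expected step is therefore a 3.0-fold lower number from compound 3 to compound 4 (0.48 log units; beyond the scatter). Compound 4 is thus estimated to give 0.6 uM in this assay, most likely between 0.3 uM and 1.5 uM.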

Compound 4, minimum effective concentration: 0.2 uM
Estimate against measurement, compound 4: 3.0-fold (0.48 log units) above; the measured number lies below the stated range.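

In this assay, hydroxymethyl in place of methoxy on an aromatic carbon lowered the number on both cores, so the direction of the change carried over from the core of compound 1 to the core of compound 3, where the step was a 9.0-fold lower number from compound 3 to compound 4 (0.95 log units; beyond the scatter). The size of the step did not carry over, and the two steps differ by more than the usual scatter of such measurements: the same change on two cores in this assay, a 3.0-fold lower number (0.48 log units; beyond the scatter) from compound 1 to compound 2 and a 9.0-fold lower number (0.95 log units; beyond the scatter) from compound 3 to compound 4, 3.0-fold (0.48 log units) apart, beyond the scatter of two such steps. These two pairs show that in this series the direction of the change held while its size depended on the core, but they do not show what in the cores sets that size, and two examples cannot say how the change would behave on any further core.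

The compounds shown leave open whether other groups at these two places, such as an aminomethyl group, a carboxylic acid or a longer chain ending in a hydroxyl, would follow the same course on both cores. They also leave open whether the gap between the two steps would persist if the butyl chain shared by all four compounds gave way to a longer chain.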